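Triazole-linked oximes: a dichloronitrophenyl variant of compound 1

A few compounds are considered here, and "the series" means these few. Any claim that something is new, unique, unknown or untested is made for them only; others in the source may bear on it.

The three measured compounds share one core and differ only in the aryl group on the triazole nitrogen. Compound 1 `CC(C)=CCC/C(C)=C/CC/C(C)=C/CC[C@@H]1[C@@]2(C)CC/C(=N\OCc3cn(-c4ccccc4)nn3)C(C)(C)[C@@H]2CC[C@@]1(C)O` carries a plain phenyl there, and in a functional assay on A549 cells (Homo sapiens) for cytotoxicity, read by MTT assay, with a stated time of 48 h (a lower number here means a stronger inhibitor, a higher number a weaker inhibitor), compound 1 gives 6160 nM, the lowest of the three numbers shown. Compound 2 `CC(C)=CCC/C(C)=C/CC/C(C)=C/CC[C@@H]1[C@@]2(C)CC/C(=N\OCc3cn(-c4cccc(Br)c4)nn3)C(C)(C)[C@@H]2CC[C@@]1(C)O` gives 11700 nM, and compound 3 `CC(C)=CCC/C(C)=C/CC/C(C)=C/CC[C@@H]1[C@@]2(C)CC/C(=N\OCc3cn(-c4cccc([N+](=O)[O-])c4)nn3)C(C)(C)[C@@H]2CC[C@@]1(C)O` gives 14800 nM.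

Compound 4 `CC(C)=CCC/C(C)=C/CC/C(C)=C/CC[C@@H]1[C@@]2(C)CC/C(=N\OCc3cn(-c4c(Cl)cc([N+](=O)[O-])cc4Cl)nn3)C(C)(C)[C@@H]2CC[C@@]1(C)O` differs from compound 1 by 2,6-dichloro-4-nitrophenyl in place of phenyl on an aromatic nitrogen. Going by the values given here, two measured steps bear on this change. Adding a bromo gave a 1.9-fold higher number from compound 1 to compound 2 (0.28 log units; within the scatter), and adding a nitro gave a 2.4-fold higher number from compound 1 to compound 3 (0.38 log units; beyond the scatter); between those two, the step of a 1.3-fold higher number from compound 2 to compound 3 (0.10 log units; within the scatter) was small. Compound 4 brings in the nitro seen in compound 3 together with two chloro groups, so a step in the same direction, and probably at least as large as that from compound 1 to compound 3, is expected. Compound 4 is therefore expected to give about 17000 nM, within a range of 8000 nM to 36000 nM, which corresponds to an expected 2.8-fold higher number from compound 1 to compound 4 (0.44 log units; beyond the scatter).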

Compound 4, half-maximal inhibitory concentration: 11200 nM
Beside the measured number, compound 4's estimate is 1.5-fold (0.18 log units) above it; measured number inside the range.
By their numbers in this assay, from the lowest: compounds 1, 4, 2 and 3 (each within the scatter of the next, the first and the last beyond it).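

In this assay, going by these compounds alone, the position on the aromatic nitrogen takes 2,6-dichloro-4-nitrophenyl in place of phenyl with a 1.8-fold higher number from compound 1 to compound 4 (0.26 log units; within the scatter) and so stays within the scatter, which the single nitro group of compound 3 did not. Within the data shown here, the new group also cannot be separated from the two singly substituted aryl groups, with a 1.3-fold lower number from compound 3 to compound 4 (0.12 log units; within the scatter) and a 1.0-fold lower number from compound 2 to compound 4 (0.02 log units; within the scatter) on the same scale, so adding two chloro groups and moving the nitro gives no step that can be read against them. Nothing shown here offers an explanation for this result.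

The compounds shown leave open what the two chloro groups do without the nitro group. They also leave open whether an amine or a carboxylic acid on the same aryl ring would bring a step beyond the scatter in either direction.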